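Ether analogues of a lysophosphatidylserine-type series

The source may report more compounds than this note shows. Statements on the series, on what has been measured and on what is new or still open speak of the compounds shown alone.

Measured in an assay on HEK293 cells for agonist activity at putative P2Y purinoceptor 10 (Mus musculus), with a stated time of 1 h; on this read-out higher numbers stand for larger maximal responses and lower numbers for smaller maximal responses:
compound 1, `CCCCCCCC/C=C\CCCCCCCC(=O)OC[C@@H](C)OP(=O)(O)OC[C@H](N)C(=O)O`: 12.4%
compound 2, `CCCCCCCC/C=C\CCCCCCCC(=O)OC[C@@H](COCC)OP(=O)(O)OC[C@H](N)C(=O)O`: "not active" (no number reported)
compound 3, `C#CCOC[C@H](COC(=O)CCCCCCC/C=C\CCCCCCCC)OP(=O)(O)OC[C@H](N)C(=O)O`: 3.2%

Compound 3 has the lower of the two numbers reported in this assay; its nearest neighbour is compound 1, and the gap between them, a number 9.2 percentage points lower from compound 1 to compound 3 (within the scatter), lies within the scatter. Compound 2 gives no number at all in this assay.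

Compound 4, `CCCCCCCC/C=C\CCCCCCCC(=O)OC[C@@H](COCc1ccccc1)OP(=O)(O)OC[C@H](N)C(=O)O`, is not yet measured. Its difference from compound 3 is phenyl in place of ethynyl on a saturated chain carbon bound to an oxygen on a saturated carbon. Within the data shown here, no measured step changes a substituent on this ether oxygen in that way; the only step available, a number 9.2 percentage points lower from compound 1 to compound 3 (within the scatter), introduces the whole propargyloxy group and is within the scatter. Both ether-bearing compounds, compound 2 and compound 3, sit at the bottom of the series, so a further ether of this kind is expected to stay low, with a fair chance of being reported as not active. The expected step of a number 1.8 percentage points higher from compound 3 to compound 4 (within the scatter) is therefore no larger than the scatter. Compound 4 is estimated at 5%, within 0% to 15%.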

Compound 4, largest response reached (Emax), in percent of the reference or control that the assay uses: 7.3%
Beside the measured number, compound 4's estimate is 2.3 percentage points below it, and the stated range covers the measured number.
By their numbers in this assay, from the lowest: compounds 3, 4 and 1 (each within the scatter of the next).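

In this assay, phenyl in place of ethynyl on a saturated chain carbon bound to an oxygen on a saturated carbon gives a number 4.1 percentage points higher from compound 3 to compound 4 (within the scatter) and so leaves the maximal response unresolved, even with an aromatic ring now in the ether group. Benzyloxy in place of hydrogen gives a number 5.1 percentage points lower from compound 1 to compound 4 (within the scatter) and, like the propargyloxy step, does not separate from compound 1, so neither ether with a number can be told apart from the compound without one. No available evidence accounts for these numbers.

Steps involving compound 2 cannot be read, since it has no number. Open, as far as these compounds go, is whether an amine or a carboxylic acid at the end of the ether group would give a response beyond the scatter of compound 1.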